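The compounds below may be only part of what the source reports. "The series", "measured", "known", "first", "only" and "open" are said of these compounds alone.

The three measured compounds share one core and differ only in the group attached to its carbonyl. Compound 1 `CCOC(=O)C1CCN(C(=O)c2cc(-c3ccc(C)cc3)nn2Cc2ccccc2)CC1` carries a piperidine ester and gives in a functional assay on the whole organism (strain Swiss albino) for inhibition, with Mus musculus as the target, read by paw edema, with stated times of 30 min and 180 min, at a dose of 100 mg/kg by the subcutaneous route (on this read-out lower numbers stand for less inhibition and higher numbers for more inhibition at the one dose given (going by the name of the read-out)), a value of 33.3%. Compound 2 `Cc1ccc(-c2cc(C(=O)NCc3cccnc3)n(Cc3ccccc3)n2)cc1` carries a pyridinylmethyl amide and gives 16.5%. Compound 3 `Cc1ccc(-c2cc(C(=O)Oc3ccc(C(C)C)cc3)n(Cc3ccccc3)n2)cc1` carries a 4-isopropylphenyl ester and gives 24%; this number sits between those of compound 2 and compound 1, yet both gaps are within the usual scatter, so the three cannot be ranked.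

Within the data shown here, the one measured step, a number 7.5 percentage points higher from compound 2 to compound 3 (within the scatter), swapped the whole group on the carbonyl and stayed within the scatter. Compound 4 `Cc1ccc(-c2cc(C(=O)Oc3ccc(Oc4ccc(C(F)(F)F)cc4)cc3)n(Cc3ccccc3)n2)cc1` keeps the aryl ester and changes only its ring substituent: 4-(trifluoromethyl)phenoxy in place of isopropyl on an aromatic carbon. Among the measured compounds shown here, no measured step touches that position, so the step from compound 2 to compound 3 is the only guide, and it was small. A step no larger than the scatter is therefore expected, and compound 4 is estimated at 25%, within 10% to 42%, meaning an expected step of a number 1 percentage points higher from compound 3 to compound 4 (within the scatter).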

Compound 4, a percentage reported as inhibition, in the whole organism at one dose (the size of the read-out at that dose, not a potency): 17%
Estimate against measurement, compound 4: 8 percentage points above; the measured number falls inside the stated range.
By their numbers in this assay, from the lowest: compounds 2, 4, 3 and 1 (each within the scatter of the next, the first and the last beyond it).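

In this assay, putting 4-(trifluoromethyl)phenoxy in place of isopropyl gave a number 7 percentage points lower from compound 3 to compound 4 (within the scatter). Among these compounds, this is the first measured change on the ring of the aryl ester, and it shows that even a large change in size, from 3 heavy atoms to 11 heavy atoms with an added aromatic ring, does not move the number beyond the usual variation at this one dose. No measurement of any property of these two groups accompanies the result, so no reason can be offered for the small difference.

Going by these compounds, it remains open whether a different kind of group at this position, such as an amine or a carboxylic acid, would separate clearly from isopropyl. A single fluorine or a methoxy group there would show whether smaller groups behave the same way.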